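Methyl on the pendant phenyl in a thiosemicarbazide series

The compounds below may be only part of what the source reports. "The series", "measured", "known", "first", "only" and "open" are said of these compounds alone.

Measured so far, in a functional assay on A549 cells (Homo sapiens) for inhibition, read by colorimetric assay and MTT assay, with a stated time of 72 h; on this read-out lower numbers stand for stronger inhibition and higher numbers for weaker inhibition:
- compound 1, `COc1cc(C(=O)NNC(=S)Nc2csc(-c3ccccc3)c2)cc(OC)c1OC`, gives 39000 nM
- compound 2, `COc1cc(C(=O)NNC(=S)Nc2csc(-c3ccc(C)cc3)c2)cc(OC)c1OC`, gives 39000 nM
- compound 3, `COc1ccc(C(=O)NNC(=S)Nc2csc(-c3ccccc3)c2)cc1`, gives 36000 nM

Compound 1 and compound 2 share one core and differ only in methyl in place of hydrogen on an aromatic carbon. The step of no change at the digits printed from compound 1 to compound 2 (within the scatter) shows that this change leaves the read-out where it was. Compound 3 carries a different core; how the core of compound 3 differs from the core of compound 1 is not broken down here, and the values of compound 1 and compound 3 lie within the usual scatter of each other, so no order between them is claimed.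

Compound 4, `COc1ccc(C(=O)NNC(=S)Nc2csc(-c3ccc(C)cc3)c2)cc1`, stands to compound 3 as compound 2 stands to compound 1: the difference is methyl in place of hydrogen on an aromatic carbon, and the place of the change reads the same word for word in both pairs, so it is the same change made on the other core.

Among the compounds with values here, only one earlier instance of this change is available, so the expectation for compound 4 rests on it alone. Because no change at the digits printed from compound 1 to compound 2 (within the scatter) was flat, the step of no change at the digits printed from compound 3 to compound 4 (within the scatter) is expected to be flat as well, with nothing among the three measured compounds pointing the other way. Compound 4 is therefore estimated at 36000 nM in this assay, with a range from 18000 nM to 72000 nM expected to cover the usual spread of repeated measurements.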

Compound 4, half-maximal inhibitory concentration: 11000 nM
For compound 4 the middle estimate is 3.3-fold (0.51 log units) above the measured one; the whole stated range lies above it.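

In this assay the change from phenyl to 4-methylphenyl does not carry over unchanged from one core to the other: the same change on two cores in this assay, no change at the digits printed (within the scatter) from compound 1 to compound 2 and a 3.3-fold lower number (0.51 log units; beyond the scatter) from compound 3 to compound 4, 3.3-fold (0.51 log units) apart, beyond the scatter of two such steps

The flat result on the core of compound 1 therefore cannot serve as a rule for the series, as the same methyl gives a 3.3-fold lower number from compound 3 to compound 4 (0.51 log units; beyond the scatter). These two pairs show that the outcome of this change differs between these two cores, but they do not show which structural difference between the cores goes with that outcome, why the steps differ, or whether either step is the more typical one for the series.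

The compounds shown leave open whether an ethyl group, a chlorine atom or a carboxylic acid in the same place on the pendant ring would follow the methyl step on either core. Also open, on these data alone, is whether the methyl change on a third core would resemble the flat step, the lower-number step or neither, which would help show how far the difference between the two pairs extends through the series.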